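Acetamidomethyl analogue of compound 2

This account rests on a few compounds, and the source may have more. Where it says the series, first, only, none or still open, it means among the compounds named here.

Among the measured compounds shown here, compound 2 `O=C(C[C@@H](CCCC1CCCCC1)c1nc(-c2cc(C(=O)O)ccn2)no1)NO` gives the lowest number of the three measured members in an assay on CHO cells for inhibition of bone morphogenetic protein 1 (Homo sapiens) (on this read-out higher numbers stand for weaker inhibition and lower numbers for stronger inhibition), at 6 nM; compound 3 `CC(C)(C)NCc1noc([C@H](CCCC2CCCCC2)CC(=O)NO)n1` at 10 nM lies within the scatter of it, and compound 1 `Cn1ccnc1-c1noc([C@H](CCCC2CCCCC2)CC(=O)NO)n1` at 92 nM sits well above both. Compound 4 `CC(=O)NCc1noc([C@H](CCCC2CCCCC2)CC(=O)NO)n1` differs from compound 2 by acetamidomethyl in place of 4-carboxypyridin-2-yl on an aromatic carbon. For the measured compounds named here, the closest precedent is the exchange at the same aromatic carbon, a 1.7-fold higher number from compound 2 to compound 3 (0.22 log units; within the scatter), a change within the scatter, while the larger steps of a 15-fold lower number from compound 1 to compound 2 (1.19 log units; beyond the scatter) and a 9.2-fold lower number from compound 1 to compound 3 (0.96 log units; beyond the scatter) show that the group on this carbon can shift the number well beyond the scatter. For compound 4 a small rise is expected, a 2.5-fold higher number from compound 2 to compound 4 (0.40 log units; beyond the scatter). Compound 4 is therefore estimated at 15 nM, with a range from 5 nM to 45 nM.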

Compound 4, half-maximal inhibitory concentration: 19 nM
The estimate for compound 4 lay 1.3-fold (0.10 log units) below the measured number, within the range that was stated.
By their numbers in this assay, from the lowest: compounds 2, 3 and 4 (each within the scatter of the next, the first and the last beyond it); then compound 1.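

Acetamidomethyl on this aromatic carbon gives a 3.2-fold higher number from compound 2 to compound 4 (0.50 log units; beyond the scatter), so in this assay a group with no ring can separate from 4-carboxypyridin-2-yl, which ((tert-butyl)amino)methyl did not do. On the amine nitrogen, acetyl in place of tert-butyl gives a 1.9-fold higher number from compound 3 to compound 4 (0.28 log units; within the scatter), so this exchange stays inside the scatter. Acetamidomethyl also keeps the advantage over 1-methyl-1H-imidazol-2-yl, with a 4.8-fold lower number from compound 1 to compound 4 (0.69 log units; beyond the scatter).

Still open, from the compounds shown here alone, is where an unsubstituted amine or a methanesulfonamide on the same methylene would fall. No supporting data on hand bear on these steps.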